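A few compounds are considered here, and "the series" means these few. Any claim that something is new, unique, unknown or untested is made for them only; others in the source may bear on it.

Compound 1 `O=C1C(Nc2ccc(Oc3ccccc3)cc2)=CC(=O)c2ncncc21` and compound 2 `NS(=O)(=O)c1ccc(NC2=CC(=O)c3ncncc3C2=O)cc1` share one core and differ in a single group. In a functional assay on PANC-1 cells (Homo sapiens) for cytotoxicity, read by MTT assay, with a stated time of 72 h (a lower number here means a stronger inhibitor, a higher number a weaker inhibitor), compound 1 gives 1800 nM. Compound 2 reaches only a limit of this assay, > 10000 nM, and so stands on a limit rather than a number, as recorded in the limit of > 10000 nM in this assay, at which 1 of the 2 values shown sits. Going by the values given here, the one measured step, an at least 5.5-fold higher number from compound 1 to compound 2 (0.74 log units; beyond the scatter), lies beyond the scatter and went with sulfamoyl entering. Compound 3 `O=C1C(Nc2ccc(OC(F)(F)F)cc2)=CC(=O)c2ncncc21` differs from compound 2 by trifluoromethoxy in place of sulfamoyl on an aromatic carbon; sulfamoyl leaves again. The expected change for compound 3 is an at least 3.3-fold lower number from compound 2 to compound 3 (0.52 log units; beyond the scatter). Compound 3 is estimated at 3000 nM, between 1000 nM and 10000 nM.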

Compound 3, half-maximal inhibitory concentration: 900 nM
The estimate for compound 3 lay 3.3-fold (0.52 log units) above the measured number; measured number below the stated range.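

At this position, an at least 11-fold lower number from compound 2 to compound 3 (1.04 log units; beyond the scatter) came with trifluoromethoxy in place of sulfamoyl, so the poor result of compound 2 does not extend to every group replacing phenoxy. Trifluoromethyl in place of phenyl on the oxygen gives a 2.0-fold lower number from compound 1 to compound 3 (0.30 log units; within the scatter), so in this assay the two cannot be told apart and the outer phenyl ring is not needed to reach this level. The size of the first step rests on a limit: the limit of > 10000 nM in this assay, at which 1 of the 3 values shown sits.

From the compounds shown here alone, whether the oxygen itself matters stays open. So does how an amine, a carboxylic acid or a longer alkyl chain would read at this position.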